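Trimming the oxane methyl groups: compound 4 in the series

This account rests on a few compounds, and the source may have more. Where it says the series, first, only, none or still open, it means among the compounds named here.

Measured compounds:
compound 1 `COc1ccccc1-n1nc(C2CC(C)(C)OC(C)(C)C2)cc1-c1ccc(Cl)cc1` — 1 nM
compound 2 `COc1ccccc1-n1nc(C2CC(C)(C)OC(C)(C)C2)cc1-c1ccc(C#N)cc1` — 1 nM
compound 3 `COc1ccccc1-n1nc(C2CC(C)(C)OC(C)(C)C2)cc1-c1ccc(C)nc1` — 6 nM

In an assay on HEK293 cells for inhibition of Voltage-dependent N-type calcium channel subunit alpha-1B (Homo sapiens), read by fluorescence and calcium flux, with a stated time of 5 min (a lower number here means a stronger inhibitor, a higher number a weaker inhibitor), compound 1 gives 1 nM, level with compound 2 at the digits shown and together the lowest of the three numbers; no change at the digits printed from compound 1 to compound 2 (within the scatter), whereas a 6.0-fold higher number from compound 1 to compound 3 (0.78 log units; beyond the scatter). Compound 4 `COc1ccccc1-n1nc(C2C[C@H](C)O[C@@H](C)C2)cc1-c1ccc(Cl)cc1` alters a different part of compound 1: 2,6-dimethyloxan-4-yl in place of 2,2,6,6-tetramethyloxan-4-yl on an aromatic carbon. Both measured steps change the group on the other side of the shared core and leave the oxane untouched, so neither bears directly on this change. Within the data shown here, with no step on the oxane to go by, the expectation for compound 4 is a modest weakening at most, a 3.0-fold higher number from compound 1 to compound 4 (0.48 log units; beyond the scatter). Compound 4 is estimated at 3 nM, with a range from 0.7 nM to 15 nM.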

Compound 4, half-maximal inhibitory concentration: 2 nM
Beside the measured number, compound 4's estimate is 1.5-fold (0.18 log units) above it, within the range that was stated.
By their numbers in this assay, from the lowest: compounds 1, 2 and 4 (each within the scatter of the next); then compound 3.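

In this assay, among these compounds, the first step on the oxane reads a 2.0-fold higher number from compound 1 to compound 4 (0.30 log units; within the scatter), so 2,6-dimethyloxan-4-yl in place of 2,2,6,6-tetramethyloxan-4-yl is not told apart from the parent by this read-out. The full tetramethyl pattern is therefore not needed for a low number here, at least with the stereocentres defined in compound 4. Nothing available speaks to the reason for this.

Still open, as far as these compounds go, is whether this position accepts an unsubstituted oxan-4-yl, a piperidin-4-yl amine or a cyclohexyl group. From the compounds shown here alone, the other stereoisomers of 2,6-dimethyloxan-4-yl also remain open.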